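The source may report more compounds than this note shows. Statements on the series, on what has been measured and on what is new or still open speak of the compounds shown alone.

Working notes on the series. In a functional assay on GBM2 cells (Homo sapiens) for antiproliferative activity, read by WST assay, with a stated time of 72 h (a higher number here means a weaker inhibitor, a lower number a stronger inhibitor), compound 1 `O=C(Nc1ccccc1F)Nc1cc2ncncc2cc1OCc1ccccc1` gives 4500 nM and compound 2 `O=C(Nc1cccc(Cl)c1)Nc1cc2ncncc2cc1OCc1cccc(Cl)c1` gives 3500 nM. For the measured compounds named here, these are the only two numbers so far. They lie within the usual scatter of each other, so compound 2 stands with compound 1 and no order can be read between them.

Compound 3 `O=C(Nc1cccc(Cl)c1)Nc1cc2ncncc2cc1OCc1ccccc1` has not yet been measured. Relative to compound 2, it carries hydrogen in place of chloro on an aromatic carbon, so that (3-chlorobenzyl)oxy becomes benzyloxy (hydrogen in place of chloro on an aromatic carbon). The 3-chlorophenyl group on the other side of the molecule stays.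

Going by the values given here, no measured pair differs in one place only, so the size of this step has no direct precedent. Compound 1 also carries benzyloxy and gives 4500 nM, a number within the scatter of compound 2. On that basis, no change beyond the scatter is expected in this assay, and no firm direction can be assigned. The estimated step of a 1.1-fold higher number from compound 2 to compound 3 (0.06 log units; within the scatter) is correspondingly small. For compound 3 the expected value is 4000 nM, with an estimated range of 2000 nM to 8000 nM.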

Compound 3, half-maximal inhibitory concentration: 4100 nM
Beside the measured number, compound 3's estimate is 1.0-fold (0.01 log units) below it, and the stated range covers the measured number.
By their numbers in this assay, from the lowest: compounds 2, 3 and 1 (each within the scatter of the next).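

The pair compound 2 and compound 3 gives the series its first reading of a change in one place on the benzyl ring in this assay (a 1.2-fold higher number from compound 2 to compound 3 (0.07 log units; within the scatter)): with the 3-chlorophenyl group held, chloro and hydrogen at this aromatic carbon cannot be told apart. For the compounds shown here, with benzyloxy held, the second step (a 1.1-fold lower number from compound 1 to compound 3 (0.04 log units; within the scatter)) is the first one-place reading on the other side of the molecule, and there too 3-chlorophenyl and 2-fluorophenyl on the amide-type nitrogen cannot be told apart. No accompanying evidence bears on these two results.

The compounds shown have only chloro or hydrogen at this aromatic carbon, so it remains open whether a group such as an amine, a carboxylic acid or methoxy there would give a step beyond the scatter. Also open, as far as these compounds go, are whether a longer chain in place of the benzyl group would do so, and whether the chloro-to-hydrogen step reads the same with 2-fluorophenyl on the amide-type nitrogen.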